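Removing the bromo substituent from the pyrazolopyrimidine core

The compounds below may be only part of what the source reports. "The series", "measured", "known", "first", "only" and "open" are said of these compounds alone.

Compound 1: `CCc1nc(N)nc2c1c(-c1ccc3oc(N)nc3c1)nn2C(C)C` — < 5 uL/min
Compound 2: `CC(C)n1nc(-c2ccc3oc(N)nc3c2)c2c(Br)nc(N)nc21` — 55 uL/min

Compound 1 carries an ethyl group on its core. In an ADME assay on cells (Hepatocyte, Homo sapiens) for metabolic stability, read by LC-MS, with a stated time of 90 min, tested at 1 uM (a higher number here means faster removal of the compound, a lower number slower removal), compound 1 gives < 5 uL/min, which is a limit of the assay rather than a number. Compound 2 places a bromo group at the same aromatic carbon, and in this assay compound 2 gives 55 uL/min. Among the values shown, this is the only one reported as a number; the other is a limit. Going by the values given here, the single measured step, an at least 11-fold higher number from compound 1 to compound 2 (1.04 log units; beyond the scatter), is large and lies beyond the scatter, and it rests on a limit at one end, (the limit of < 5 uL/min in this assay, at which 1 of the 2 values shown sits).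

Compound 3, `CC(C)n1nc(-c2ccc3oc(N)nc3c2)c2cnc(N)nc21`, is to be measured in this assay. It differs from compound 2 as follows: hydrogen in place of bromo on an aromatic carbon. Among the compounds with values here, the one measured step bears on it only in showing that what sits at this carbon can move the number a great deal, so a step beyond the scatter is plausible in either direction. Compound 3 is therefore expected to give 30 uL/min, with a range from 8 uL/min to 100 uL/min, which means an expected step of a 1.8-fold lower number from compound 2 to compound 3 (0.26 log units; within the scatter).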

Compound 3, intrinsic clearance in a liver preparation (reported as CLH), per the amount of preparation that the assay uses: 150 uL/min
For compound 3 the middle estimate is 5.0-fold (0.70 log units) below the measured one; the measured number lies above the stated range.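

With hydrogen on this carbon of the shared core, the series now has a reference point that the earlier pair lacked: hydrogen in place of bromo gives a 2.7-fold higher number from compound 2 to compound 3 (0.44 log units; beyond the scatter) in this assay, so the bromo group, which had looked like the poor end of the comparison with ethyl, goes with a lower number than the bare carbon. Hydrogen in place of ethyl gives an at least 30-fold higher number from compound 1 to compound 3 (1.47 log units; beyond the scatter), a larger step, so among these three compounds both substituents go with slower removal than hydrogen, and ethyl goes further in that direction than bromo. The value of compound 1 is a limit of the assay and not a number, and the size of that step is a bound only: the limit of < 5 uL/min in this assay, at which 1 of the 3 values shown sits.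

What the compounds shown leave open is how other groups would behave on this carbon, such as chloro, methoxy, an amine or a longer chain than ethyl. They also leave open whether this order of hydrogen, bromo and ethyl would hold with a different group on the rest of the core, and they give no reason for the order.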